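A Naphthalen-1-yl Swap on the Shared Core

The source may hold more compounds than are shown below. What is called first, only, known or untested is meant among the compounds shown, and "the series" means these compounds.

The measured compounds are these. Compound 1 `c1ccc2c(-c3cn4ccnc4c(-c4ccc5ncn(C6CCCCC6)c5c4)n3)cccc2c1`: in a functional assay on SK-MEL-2 cells (Homo sapiens) for inhibition, read by sulforhodamine B assay, with a stated time of 48 h, tested at 10 uM (on this read-out higher numbers stand for more inhibition at the one concentration tested (going by the name of the read-out) and lower numbers for less inhibition), compound 1 gives 2.3%. Compound 2 `Brc1ccc(-c2cn3ccnc3c(-c3ccc4ncn(C5CCCCC5)c4c3)n2)cc1`: compound 2 gives 24.1%. Compound 3 `Cc1cccc(-c2cn3ccnc3c(-c3ccc4ncn(Cc5ccccc5)c4c3)n2)c1`: compound 3 gives 6.34%.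

Compound 3 stands second highest of the three numbers. Its nearest neighbour is compound 1, whose number is lower but within the scatter, so the two cannot be ordered. Compound 2 stands beyond the scatter above compound 3.

The unmeasured compound 4 `c1ccc(Cn2cnc3ccc(-c4nc(-c5cccc6ccccc56)cn5ccnc45)cc32)cc1` differs from compound 3 in one place: naphthalen-1-yl in place of 3-methylphenyl on an aromatic carbon.

Within the data shown here, only one measured step bears on this change, a number 21.8 percentage points higher from compound 1 to compound 2 (beyond the scatter), and it runs away from naphthalen-1-yl rather than towards it, with a different group at the other end. Read backwards, it suggests that naphthalen-1-yl sits on the lower side of the aryl groups seen so far, and compound 1, the one measured compound carrying naphthalen-1-yl, gives the lowest number of the three. Compound 3 itself already sits low. The expected step for compound 4 is therefore a number 2.3 percentage points lower from compound 3 to compound 4 (within the scatter), a change not expected to reach beyond the scatter. Compound 4 is estimated at 4%, within a range of -8% to 16%.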

Compound 4, a percentage reported as inhibition, at one concentration (the size of the read-out at that concentration, not a potency): 17%
Compound 4: middle estimate off by 13 percentage points, on the low side; measured number above the stated range.
By their numbers in this assay, from the lowest: compounds 1 and 3 (each within the scatter of the next); then compounds 4 and 2 (each within the scatter of the next).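

In this assay, placing naphthalen-1-yl on this aromatic carbon in place of 3-methylphenyl gives a number 10.7 percentage points higher from compound 3 to compound 4 (beyond the scatter), so on a benzyl-bearing core naphthalen-1-yl does not go with a low number, as the cyclohexyl pair alone had suggested. With naphthalen-1-yl held in place, benzyl in place of cyclohexyl on the aromatic nitrogen gives a number 14.7 percentage points higher from compound 1 to compound 4 (beyond the scatter), which shows that the group on that nitrogen also moves the read-out and that the earlier low number of naphthalen-1-yl cannot be read as belonging to the aryl group alone. The data at hand offer no explanation for either step.

Among the compounds shown, 4-bromophenyl appears only with cyclohexyl and 3-methylphenyl only with benzyl, so it remains open whether the aryl and nitrogen changes act independently or depend on each other. Going by these compounds, it also remains open how the read-out would respond to a carboxylic acid or an amine on the aryl ring, or to a longer chain such as 2-phenylethyl in place of benzyl on the aromatic nitrogen.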